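A Longer Arm to the Aminophenyl Amide

This account rests on a few compounds, and the source may have more. Where it says the series, first, only, none or still open, it means among the compounds named here.

Three compounds have numbers in a functional assay on NCI-H460 cells (Homo sapiens) for antiproliferative activity, read by CCK-8 assay, with a stated time of 72 h, tested at 8 uM; a higher number here means a stronger effect of the compound at the concentration tested, a lower number a weaker effect:

Compound 1, `CC(C)n1cnc2c(Nc3ccccc3)nc(NCOCc3ccc(/C=C/C(=O)Nc4ccccc4N)cc3)nc21`, gives 53.1%.
Compound 2, `Nc1ccccc1NC(=O)c1ccc(COCNc2nc(Nc3ccccc3)c3ncn(C4CCCC4)c3n2)cc1`, gives 56.1%.
Compound 3, `Nc1ccccc1NC(=O)c1ccc(COCNc2nc(Nc3ccc(-c4ccccc4)cc3)c3ncn(C4CCCC4)c3n2)cc1`, gives 41.6%.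

Compound 2 has the highest of the three numbers in this assay. Its nearest neighbour is compound 1, whose value lies within the scatter of that of compound 2, so the two cannot be ordered. Compound 3 lies furthest away; the step of a number 14.5 percentage points lower from compound 2 to compound 3 (beyond the scatter) is a modest loss beyond the scatter, and it goes with phenyl in place of hydrogen on an aromatic carbon.

The compound to be estimated is compound 4, `Nc1ccccc1NC(=O)/C=C/c1ccc(COCNc2nc(Nc3ccccc3)c3ncn(C4CCCC4)c3n2)cc1`. It differs from compound 2 in one place: 2-((2-aminophenyl)carbamoyl)ethenyl in place of (2-aminophenyl)carbamoyl on an aromatic carbon

For the measured compounds named here, no measured step matches this change. Compound 1 carries the same ethenyl-linked amide, but it also differs from compound 2 elsewhere, so its value and that of compound 2 can only be set side by side; they fall within the scatter of each other. Going by the values given here, the one measured step, a number 14.5 percentage points lower from compound 2 to compound 3 (beyond the scatter), concerns a different position and does not bear on the change to compound 4.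

On this basis no step beyond the scatter is expected in this assay. Compound 4 is expected to give 54%, in the range 40% to 67%, which means an estimated step of a number 2.1 percentage points lower from compound 2 to compound 4 (within the scatter).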

Compound 4, a percentage reported as inhibition, at one concentration (the size of the read-out at that concentration, not a potency): 59.7%
Compound 4: middle estimate off by 5.7 percentage points, on the low side; the range from low to high includes it.
By their numbers in this assay, from the lowest: compound 3; then compounds 1, 2 and 4 (each within the scatter of the next).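

In this assay, putting 2-((2-aminophenyl)carbamoyl)ethenyl in place of (2-aminophenyl)carbamoyl, on the aromatic carbon para to a large group, gives a number 3.6 percentage points higher from compound 2 to compound 4 (within the scatter) and so provides a direct one-place reading of this change, which the side-by-side view of compound 1 and compound 2 could not give. For the compounds shown here, the two values cannot be ordered, so the added ethenyl unit brings no measurable step at this position in this read-out at the single concentration tested. Compound 4 also isolates a second change with the ethenyl-linked amide held constant: cyclopentyl in place of isopropyl on an aromatic nitrogen gives a number 6.6 percentage points higher from compound 1 to compound 4 (within the scatter) and is likewise no measurable step, and no evidence here speaks to why either change leaves the read-out within the scatter.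

On these data alone, it remains open whether a saturated ethylene link, a longer chain or a hydroxamic acid in place of the 2-aminophenyl amide would keep a number in this range. Also open, as far as these compounds go, is whether the phenyl group behind a number 14.5 percentage points lower from compound 2 to compound 3 (beyond the scatter) would go with a step of similar size when the ethenyl-linked amide is present.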